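Piperidin-4-yl to Piperidin-2-yl: Expecting Compound 4

A few compounds are considered here, and "the series" means these few. Any claim that something is new, unique, unknown or untested is made for them only; others in the source may bear on it.

Of the compounds shown here, three sharing one core have been measured in an assay on isolated protein for binding affinity to Neuropeptide Y receptor type 1 (Homo sapiens); on this read-out lower numbers stand for stronger inhibition and higher numbers for weaker inhibition. Compound 1 `Clc1ccc(OCc2nc3c(OCCC4CCNCC4)cccc3n2CCCC2CCCNC2)cc1` gives 7 nM. Among the measured compounds shown here, compound 2 `Oc1cccc2c1nc(COc1ccc(Cl)cc1)n2CCCC1CCCNC1` gives 5300 nM, and the only single-point step in the set, a 760-fold higher number from compound 1 to compound 2 (2.88 log units; beyond the scatter), comes from putting hydrogen in place of 2-(piperidin-4-yl)ethyl on an oxygen on an aromatic ring. Compound 3 `Clc1ccc(OCc2nc3ccccc3n2CCCC2CCNCC2)cc1` gives 980 nM in this assay, which places it between compound 1 and compound 2, nearer to compound 2.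

Compound 4 `Clc1ccc(OCc2nc3ccccc3n2CCCC2CCCCN2)cc1` has not yet been measured. It differs from compound 3 by piperidin-2-yl in place of piperidin-4-yl on a saturated chain carbon, three bonds along the chain from an aromatic nitrogen. For the measured compounds named here, no measured step touches this part of the molecule; the single known step alters a different substituent and so gives no direct guide. With nothing pointing either way, the expectation for compound 4 in this assay is a step of a 1.2-fold higher number from compound 3 to compound 4 (0.09 log units; within the scatter), within the scatter, and an estimated 1200 nM with a range from 300 nM to 5000 nM.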

Compound 4, inhibition constant: 3230 nM
Beside the measured number, compound 4's estimate is 2.7-fold (0.43 log units) below it; the range from low to high includes it.
By their numbers in this assay, from the lowest: compound 1; then compound 3; then compounds 4 and 2 (each within the scatter of the next).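

In this assay, the change gives a 3.3-fold higher number from compound 3 to compound 4 (0.52 log units; beyond the scatter), which is beyond the scatter. Among the compounds shown here, this is the first measured step at this position, and it shows that the read-out responds to how the ring is joined to the chain, even though the two compounds have the same atoms and the groups have the same counted features. The step is modest, whereas a 760-fold higher number from compound 1 to compound 2 (2.88 log units; beyond the scatter) is large, and nothing available explains why the point of attachment matters here.

On these data alone, it remains open how piperidin-3-yl, the ring carried by compound 1 and compound 2, would read on the otherwise bare core of compound 3. Also open, as far as these compounds go, is what a pyrrolidin-2-yl ring or an open-chain primary amine would give at this position.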